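This account rests on a few compounds, and the source may have more. Where it says the series, first, only, none or still open, it means among the compounds named here.

Working notes on the series. Compound 1 `COc1cc2c(cc1OC)CN(Cc1ccc(OC)c3oc(-c4ccccc4C(F)(F)F)cc13)CC2` gives 18 nM in an assay on HepG2 cells for displacement of a labelled ligand from Alpha-2C adrenergic receptor (Homo sapiens); a lower number here means a stronger inhibitor, a higher number a weaker inhibitor; this is the highest of the two numbers recorded so far. Its nearest neighbour is compound 2 `COc1cc2c(cc1OC)CN(Cc1ccc(OC)c3oc(-c4cccc(C(=O)NCCN(C)C)c4)cc13)CC2`, which in this assay gives 9.4 nM; the gap between the two lies within the scatter, so no ranking of compound 1 against compound 2 is claimed.

Compound 3 `COc1cc2c(cc1OC)CN(Cc1ccc(OC)c3oc(C(=O)NCC(C)(C)N)cc13)CC2` is the next point, not yet measured. Relative to compound 1 the change is (2-amino-2-methylpropyl)carbamoyl in place of 2-(trifluoromethyl)phenyl on an aromatic carbon: the whole aromatic group on the five-membered ring is exchanged for an open-chain carbamoyl bearing a primary amine. Going by the values given here, no measured pair in the set covers a change of this kind, so nothing measured anchors the size of the step. Both measured compounds keep an aromatic group at this position, and its loss is expected to cost some binding; the estimated step from compound 1 to compound 3 in this assay is a 3.3-fold higher number from compound 1 to compound 3 (0.52 log units; beyond the scatter), towards a higher number. Compound 3 is therefore estimated at 60 nM, with a range from 12 nM to 300 nM.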

Compound 3, inhibition constant: 4.2 nM
Estimate against measurement, compound 3: 14-fold (1.15 log units) above, and the stated range ends above it.
By their numbers in this assay, from the lowest: compound 3; then compounds 2 and 1 (each within the scatter of the next).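

In this assay, the place on the five-membered aromatic ring next to the ring oxygen does not depend on an aromatic group: (2-amino-2-methylpropyl)carbamoyl in place of 2-(trifluoromethyl)phenyl gives a 4.3-fold lower number from compound 1 to compound 3 (0.63 log units; beyond the scatter) and thus a modest gain rather than a loss. An open-chain carbamoyl bearing a primary amine, with no ring, is therefore accepted here on the shared core, while hydrogen-bond donors and acceptors enter where the departing group had none. Nothing available explains the lower number, and a change this large cannot be assigned to any single part of the new group.

As far as these compounds go, it remains open whether the carbamoyl alone carries the gain or the amine is also required. A hydroxyl or a carboxylic acid in place of the amine, or a longer chain between it and the carbamoyl, would separate these parts.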